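Hydroxy removal on the sulfonamide chain: working notes

This account rests on a few compounds, and the source may have more. Where it says the series, first, only, none or still open, it means among the compounds named here.

Measured so far:
compound 1, `CC[C@@H]1C(=O)N(C)c2cnc(-n3ccc4cc(F)ccc43)nc2N1C1CCCC1`: 16000 nM
compound 2, `CCC1C(=O)N(C)c2cnc(Nc3ccc(S(=O)(=O)NCCCO)cc3)nc2N1c1ccn(C)n1`: "not active" (no number reported)

In a functional assay on Huh-7 cells (Homo sapiens) for antiproliferative activity, read by CCK-8 assay, with a stated time of 72 h (on this read-out higher numbers stand for weaker inhibition of growth and lower numbers for stronger inhibition of growth), compound 1 gives 16000 nM. In this assay compound 2 gives "not active" (no number reported), so no number stands against it; on the figures shown, compound 2 has no place on the scale, and nothing more can be read from the pair with compound 1.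

Compound 3, `CCCNS(=O)(=O)c1ccc(Nc2ncc3c(n2)N(c2ccn(C)n2)C(CC)C(=O)N3C)cc1`, is the next point. The change is hydrogen in place of hydroxy on a saturated chain carbon, three bonds along the chain from a sulfonamide nitrogen. Among the measured compounds shown here, no step between measured compounds exists to set a size for this change. The expectation is therefore that compound 3 stays near where compound 2 sits, with no shift beyond the scatter in either direction, and a high chance that this assay again reports no number. Compound 3 is estimated at 40000 nM, in the range 10000 nM to 150000 nM.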

Compound 3, concentration for 50% growth inhibition: 8880 nM
Estimate against measurement, compound 3: 4.5-fold (0.65 log units) above, and the stated range ends above it.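

No step can be read from compound 2 to compound 3: in this assay compound 3 gives 8880 nM while compound 2 carries no number. The compounds shown leave open how large the change from 3-hydroxypropyl to propyl is. No evidence at hand bears on this result.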